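Pyrrole-linked salicylic acids: thiophene for methylphenyl

This account rests on a few compounds, and the source may have more. Where it says the series, first, only, none or still open, it means among the compounds named here.

Measured in a functional assay on the whole organism (strain Wistar) for inhibition, with Rattus norvegicus as the target, read by paw edema, with stated times of 30 min and 3 h, at a dose of 200 mg/kg by the oral route; a higher number here means more inhibition at the dose given (going by the name of the read-out), a lower number less inhibition:
compound 1 `O=C(O)c1ccc(-n2c(-c3ccccc3)cc3c2CCCC3)cc1O` gives 0%
compound 2 `O=C(O)c1cc(-n2c(-c3ccccc3)cc3c2CCCC3)c(C(F)(F)F)cc1O` gives 0%
compound 3 `Cc1ccc(-c2cc3c(n2-c2ccc(O)c(C(=O)O)c2)CCCC3)cc1` gives 30%

Compound 3 stands highest of the three numbers. Its nearest neighbour is compound 1, which lies lower by a distance beyond the scatter; compound 2 lies lower by the same distance, also beyond the scatter. Compounds 1 and 2, each carrying an unsubstituted phenyl, show no inhibition at all, so the whole measured activity of the series rests on compound 3.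

Compound 4 `O=C(O)c1cc(-n2c(-c3cccs3)cc3c2CCCC3)ccc1O` follows from compound 3 by thiophen-2-yl in place of 4-methylphenyl on an aromatic carbon. Among the compounds with values here, no step between two measured compounds is available to size this change, so the expectation rests only on the spread seen so far. A downward step of moderate size is expected in this assay, a number 15 percentage points lower from compound 3 to compound 4 (beyond the scatter), since compound 3 with its 30% carries the group that leaves. Compound 4 is therefore expected to give 15%, within a range from 0% to 35%.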

Compound 4, a percentage reported as inhibition, in the whole organism at one dose (the size of the read-out at that dose, not a potency): 30%
For compound 4 the middle estimate is 15 percentage points below the measured one; low and high end bracket the measured number.
By their numbers in this assay, from the lowest: compounds 1 and 2 (each within the scatter of the next); then compounds 3 and 4 (each within the scatter of the next).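

In this assay, thiophen-2-yl in place of 4-methylphenyl on this aromatic carbon, next to the ring nitrogen, gives no change at the digits printed from compound 3 to compound 4 (within the scatter). Within the data shown here, this is the first readable step at this place, and it shows that a five-membered aromatic ring with a sulfur atom, with fewer heavy atoms and a hydrogen-bond acceptor that the leaving group lacks, serves here as well as the methyl-bearing six-membered ring at this one dose. Nothing measured here bears on why the number holds.

Going by these compounds, whether furan-2-yl, pyridin-2-yl or 4-chlorophenyl at this carbon would hold the same number remains open. Because the read-out is a single-dose percentage and not a potency, matching numbers for compound 3 and compound 4 also leave open how the two compare across a range of doses.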